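Swapping 4-chlorophenyl for pyridin-3-yl in a stability test

The compounds below may be only part of what the source reports. "The series", "measured", "known", "first", "only" and "open" are said of these compounds alone.

Of the compounds shown here, three that share an octyl-bearing aromatic end have been measured so far. In an ADME assay on S9 fraction from liver (Rattus norvegicus) for metabolic stability, read by LC-MS, using NADPH, with a stated time of 30 min (a lower number here means that less of the compound is left, a higher number that more of the compound is left), compound 1 `CCCCCCCCc1ccc(OCC(=O)Cn2nnc(-c3cccc(C(=O)O)c3)n2)cc1` gives < 5%, which is a limit of the assay and not a number. Going by the values given here, compound 2 `CCCCCCCCc1ccc(OCC(=O)Cn2nnnc2C)cc1` gives 32%, and compound 3 `CCCCCCCCc1ccc(OCC(=O)Cn2nnnc2-c2ccc(Cl)cc2)cc1` gives 45%, the higher of the only two true numbers available.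

The next compound, compound 4 `CCCCCCCCc1ccc(OCC(=O)Cn2nnnc2-c2cccnc2)cc1`, keeps the rest of compound 3 and changes one group: pyridin-3-yl in place of 4-chlorophenyl on an aromatic carbon. In words, pyridin-3-yl stands in place of 4-chlorophenyl on an aromatic carbon.

Among the compounds with values here, only one measured step bears on this position: a number 13 percentage points higher from compound 2 to compound 3 (beyond the scatter), with 4-chlorophenyl in place of methyl. That step was modest, and it shows that the group at this place can shift the result in this assay. Within the data shown here, it does not test pyridin-3-yl, however, and no measured compound carries a ring with a hetero atom there. A large move therefore has no support, and the expectation stays close to the value of compound 3, with a slight lean downward.

The estimated change is a number 6 percentage points lower from compound 3 to compound 4 (within the scatter), which is expected to stay small. For compound 4 the expected value is 39%, with an estimated range from 20% to 58%.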

Compound 4, percent of the compound remaining: 20%
Estimate against measurement, compound 4: 19 percentage points above; the measured number falls inside the stated range.
By their numbers in this assay, from the lowest: compound 4; then compound 2; then compound 3. At a limit, below all of these: compound 1.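

In this assay, the change to pyridin-3-yl gives a number 25 percentage points lower from compound 3 to compound 4 (beyond the scatter), which shows that this place on the five-membered aromatic ring responds to which ring it carries, not merely to whether it carries one. The earlier step from methyl to 4-chlorophenyl could be read as a ring simply raising the number, but pyridin-3-yl in place of methyl gives a number 12 percentage points lower from compound 2 to compound 4 (beyond the scatter), so compound 3 fits that reading and compound 4 goes against it. None of the information shown gives a measured property that accounts for the different results with these two rings.

The change to compound 4 removes the chlorine and brings in a ring nitrogen at the same time, so the compounds shown cannot say how much of the fall belongs to each of the two. A plain phenyl ring at this place would separate those two parts of the change, and a pyridine ring carrying a chlorine would show whether the two parts act independently of each other.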